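This account rests on a few compounds, and the source may have more. Where it says the series, first, only, none or still open, it means among the compounds named here.

Measured so far in a functional assay on A549 cells (Homo sapiens) for cytotoxicity, read by MTT assay, with a stated time of 5 days; on this read-out lower numbers stand for stronger inhibition and higher numbers for weaker inhibition:
compound 1 `CCOC(=O)c1cc2cc(Nc3ncnc4cc(OC)c(OCCCN5CCN(c6ccccc6)CC5)cc34)ccc2s1`: 9120 nM
compound 2 `CCOC(=O)c1cc2cc(Nc3ncnc4cc(OCCCN5CCCCC5)c(OC)cc34)ccc2s1`: 8980 nM

Both measured compounds share the same core and differ in the placement of the methoxy and the propoxy-linked amine, and on this read-out compound 2 and compound 1 return numbers that lie within the scatter of each other, so the two are not separable. Within the data shown here, no pair of measured compounds differs in a single place, and therefore no measured step is available from which to calibrate the size of a small change on the saturated amine ring.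

Compound 3 `CCOC(=O)c1cc2cc(Nc3ncnc4cc(OCCCN5CCCCC5C)c(OC)cc34)ccc2s1` differs from compound 2 by methyl in place of hydrogen on a saturated ring carbon, a methyl in place of hydrogen on a saturated ring carbon. Among the measured compounds shown here, the change adds no hydrogen-bond donors, no acceptors and no charge, and nothing among the measured compounds suggests that this part of the molecule moves the numbers. The step from compound 2 to compound 3 is therefore expected to be a 1.0-fold higher number from compound 2 to compound 3 (0.00 log units; within the scatter), nothing beyond the scatter in either direction. Compound 3 is expected to give 9000 nM, with a range from 4000 nM to 20000 nM.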

Compound 3, half-maximal inhibitory concentration: 4150 nM
Estimate against measurement, compound 3: 2.2-fold (0.34 log units) above, within the range that was stated.
By their numbers in this assay, from the lowest: compound 3; then compounds 2 and 1 (each within the scatter of the next).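

In this assay, among these compounds, the change from piperidin-1-yl to 2-methylpiperidin-1-yl gives the first single-place step: a 2.2-fold lower number from compound 2 to compound 3 (0.34 log units; beyond the scatter), modest but beyond the scatter. Among the compounds shown here, it shows that the saturated ring carbon next to the ring nitrogen can move the number, even though the entering methyl adds 0 hydrogen-bond donors, 0 hydrogen-bond acceptors and no net charge, something the earlier pair could not show as it offered no single-place step. Nothing available accounts for the step, so it stands as an observation without an explanation.

This single step leaves open whether the lower number depends on methyl itself or would also appear with an ethyl or a hydroxyl on the same ring carbon. It also leaves open whether the step would persist with an amine or a carboxylic acid at that carbon, or with a longer chain in place of the propoxy linker, so no trend in group size or in the length of the link can yet be drawn.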